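The source may report more compounds than this note shows. Statements on the series, on what has been measured and on what is new or still open speak of the compounds shown alone.

Measured compounds:
- Compound 1, `O=C(Nc1ccc(Oc2ccccc2)cc1)Oc1ccccc1F`: 1300 nM
- Compound 2, `CCCCOc1ccc(C(CC)NC(=O)Oc2cccc(C(F)(F)F)c2)cc1`: 51 nM
- Compound 3, `CCCCCCCCOc1ccc(NC(=O)O/N=C/c2cccnc2)cc1`: 0.8 nM

All three were tested in an assay on H4 cells for inhibition of Fatty-acid amide hydrolase 1 (Homo sapiens); a lower number here means a stronger inhibitor, a higher number a weaker inhibitor. Compound 1 gives 1300 nM, the highest number among the three, so it is the weakest inhibitor in this small set. Compound 2 reaches 51 nM and compound 3 reaches 0.8 nM; both carry a chain on the oxygen of the aromatic ring rather than a second ring, and both sit far below compound 1 in this assay.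

Compound 4, `CCCCCCOc1ccc(NC(=O)Oc2ccccc2F)cc1`, has not yet been measured. It differs from compound 1 in a single spot: hexyl in place of phenyl on an oxygen on an aromatic ring. The carbamate and the fluorinated ring that compound 1 carries are kept unchanged, so only the group on the aromatic oxygen is altered.

Within the data shown here, no measured pair in the set shows this exact exchange, so the size of the step cannot be read from the data directly. Still, compound 2 with 51 nM and compound 3 with 0.8 nM both carry such a chain and give much lower numbers than compound 1. On that basis a step in the downward direction, toward stronger inhibition and clearly beyond the usual scatter, is expected for compound 4, namely a 26-fold lower number from compound 1 to compound 4 (1.41 log units; beyond the scatter). Compound 4 is therefore estimated at 50 nM, with a likely range from 5 nM to 500 nM.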

Compound 4, half-maximal inhibitory concentration: 710 nM
Compound 4: the middle estimate sits 14-fold (1.15 log units) below what was measured; the whole stated range lies below it.
By their numbers in this assay, from the lowest: compound 3; then compound 2; then compounds 4 and 1 (each within the scatter of the next).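

In this assay, putting hexyl in place of phenyl on the oxygen on the aromatic ring gives a 1.8-fold lower number from compound 1 to compound 4 (0.26 log units; within the scatter), so this exchange of a ring for an open chain, each with 6 heavy atoms, leaves no change that can be told from the usual spread of repeated measurements. With the carbamate and the fluorinated ring of compound 1 kept, a hexyl chain on this oxygen is therefore not enough on its own to give a clearly stronger inhibitor, and the chains on compound 2 and compound 3 cannot be credited with their low numbers, as each differs from compound 4 in more than one place. Nothing available explains why the exchange makes so little difference.

Still open, on these data alone, is whether a decyl chain, or a hexyl chain ending in an amine or a carboxylic acid, would shift the number for compound 4 beyond the scatter. Also open is which single change elsewhere on the core of compound 4 would do so, since no compound shown isolates one.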